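Swapping methoxy for hydroxyethylamino on the pyrimidine core

The source may report more compounds than this note shows. Statements on the series, on what has been measured and on what is new or still open speak of the compounds shown alone.

Three ureas sharing one core have been tested in an assay on isolated protein for inhibition of serine/threonine-protein kinase TNNI3K (Homo sapiens); a lower number here means a stronger inhibitor, a higher number a weaker inhibitor. Compound 2 `COc1cc(Oc2ccc(NC(=O)Nc3cccc(C(F)(F)F)c3)cc2)ncn1` gives 4000 nM, the second highest of the three numbers. Compound 1 `CNc1cc(Oc2ccc(NC(=O)Nc3ccccc3)cc2)ncn1` gives 6300 nM, which lies within the scatter of compound 2. Compound 3 `CNc1cc(Oc2ccc(NC(=O)Nc3cccc(C(F)(F)F)c3)c(F)c2)ncn1` differs from compound 2 in two places. In this assay compound 3 gives 63 nM, far lower. Compound 4 `O=C(Nc1ccc(Oc2cc(NCCO)ncn2)cc1)Nc1cccc(C(F)(F)F)c1` is not yet measured; it differs from compound 2 by (2-hydroxyethyl)amino in place of methoxy on an aromatic carbon. Going by the values given here, no single-change step between measured compounds shows what this swap does. Compound 3, carrying an alkylamino group on the same carbon, is the most potent here, so a modest gain is expected, with the step from compound 2 to compound 4 estimated as a 4.0-fold lower number from compound 2 to compound 4 (0.60 log units; beyond the scatter). Compound 4 is expected to give about 1000 nM, within 200 nM to 5000 nM.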

Compound 4, half-maximal inhibitory concentration: 32 nM
Compound 4: the middle estimate sits 31-fold (1.49 log units) above what was measured; the measured number lies below the stated range.
By their numbers in this assay, from the lowest: compounds 4 and 3 (each within the scatter of the next); then compounds 2 and 1 (each within the scatter of the next).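

In this assay, (2-hydroxyethyl)amino in place of methoxy on this aromatic carbon gives a 130-fold lower number from compound 2 to compound 4 (2.10 log units; beyond the scatter), a large step. Going by these compounds alone, this is the first comparison that changes this position alone, so the earlier compounds, which differ in two places, could not show that this swap by itself can shift the number so far. Nothing available explains the size of this step. From the compounds shown here alone, whether the hydroxyl matters remains open. An ethylamino group or a longer chain such as (3-hydroxypropyl)amino at this position would help to test that.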